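A few compounds are considered here, and "the series" means these few. Any claim that something is new, unique, unknown or untested is made for them only; others in the source may bear on it.

Measured compounds:
- compound 1, `C/C=C/C(=O)N(Cc1cccc(O)c1)c1cc(OC)c(OC)c(OC)c1`: 14700 nM
- compound 2, `CCC/C=C/C(=O)N(Cc1ccc(OC)c(O)c1)c1cc(OC)c(OC)c(OC)c1`: 57 nM
- compound 3, `COc1cc(NCc2cccc(O)c2)cc(OC)c1OC`: 71300 nM

These numbers come from a functional assay on KYSE-450 cells (Homo sapiens) for inhibition, read by MTT assay, with a stated time of 48 h; a higher number here means a weaker inhibitor, a lower number a stronger inhibitor. Among the three, compound 3 gives the highest number, so it is the weakest inhibitor here; its nearest neighbour is compound 1, and the step between them is a 4.9-fold higher number from compound 1 to compound 3 (0.69 log units; beyond the scatter). Within the data shown here, compound 2, which differs from compound 1 in two places, gives a far lower number, but no single step connects it to compound 3.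

The unmeasured compound 4 is `COc1cc(NCc2ccc(Cl)cc2)cc(OC)c1OC`. It differs from compound 3 in one place: 4-chlorophenyl in place of 3-hydroxyphenyl on a saturated chain carbon bound to a nitrogen on an aromatic ring. The shared core and the nitrogen bound to a saturated chain carbon stay as they are.

Among the measured compounds shown here, none of the measured steps touches the group on that saturated chain carbon; the one step seen, from compound 1 to compound 3, concerns the nitrogen, not this aryl ring. There is therefore no direct guide to how large the swap will be. For the measured compounds named here, with no bearing step, the expectation is a change of modest size at most, in either direction, and quite possibly none beyond the scatter; the step from compound 3 is expected to be a 1.2-fold lower number from compound 3 to compound 4 (0.07 log units; within the scatter). For compound 4 the estimated value is 60000 nM, with a range from 20000 nM to 200000 nM.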

Compound 4, half-maximal inhibitory concentration: > 80000 nM
Compound 4 was reported as a limit (the forecaster's own chance of this, stated with the estimate: 25%); middle value at least 1.3-fold (0.12 log units) from the limit.
By their numbers in this assay, from the lowest: compound 2; then compound 1; then compound 3. At a limit, above all of these: compound 4.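

In this assay compound 4 gives > 80000 nM, which is a limit of the assay and not a number. From the compounds shown here alone, putting 4-chlorophenyl in place of 3-hydroxyphenyl on the saturated chain carbon gives an at least 1.1-fold higher number from compound 3 to compound 4 (0.05 log units; that floor lies within the scatter), so the smallest change this allows is no real change, and how far the true step goes remains unknown. Among these compounds, this is the first view of this aryl group, which the earlier step at the nitrogen did not touch, and it shows that the swap, which gives up the hydrogen-bond donor and acceptor counted on 3-hydroxyphenyl, brings no lower number to a compound with a free hydrogen on that nitrogen.

Since the swap removes the hydroxyl and adds the chlorine at once, the two changes cannot be told apart, and a plain phenyl group in the same place would be needed to separate them. Going by these compounds, it also remains open whether 4-chlorophenyl would behave the same way with a (prop-1-en-1-yl)carbonyl group on the nitrogen, as in compound 1, or with a longer chain in that acyl group, as in compound 2.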